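Phenoxy for methoxy on a difluoro quinolone core: cytotoxicity

The source may report more compounds than this note shows. Statements on the series, on what has been measured and on what is new or still open speak of the compounds shown alone.

Measured so far:
compound 1 `CCOC(=O)c1c(-c2cccc(OC)c2)[nH]c2cc(OC)ccc2c1=O`, > 21500 nM
compound 2 `CCOC(=O)c1c(-c2cccc(Oc3ccccc3)c2)[nH]c2cc(OC)ccc2c1=O`, > 21500 nM
compound 3 `CCOC(=O)c1c(-c2cccc(OC)c2)[nH]c2cc(F)cc(F)c2c1=O`, > 21500 nM

In an ADME assay on HepG2 cells (Homo sapiens) for cytotoxicity, read by luminescence, with a stated time of 72 h (on this read-out higher numbers stand for an effect only at larger amounts of compound and lower numbers for an effect already at smaller amounts), compound 1 gives > 21500 nM, a limit of the assay. Compound 2 likewise gives > 21500 nM, again only a limit. The change between them, (phenyl in place of methyl on an oxygen on an aromatic ring), yields a step that the two limits leave unreadable from compound 1 to compound 2. The same picture holds at the limit of > 21500 nM in this assay, at which 3 of the 3 values shown sit.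

Compound 3 gives > 21500 nM, a limit as well. How its core differs from the core of compound 1 is not broken down here. Compound 4 `CCOC(=O)c1c(-c2cccc(Oc3ccccc3)c2)[nH]c2cc(F)cc(F)c2c1=O` has not yet been measured; it differs from compound 3 by phenyl in place of methyl on an oxygen on an aromatic ring, which is the same change as from compound 1 to compound 2, since both place lines read alike.

Because the limit of > 21500 nM in this assay, at which 3 of the 3 values shown sit, gathers every value shown, the step is expected to be a step that the limit leaves unreadable from compound 3 to compound 4, with compound 4 most likely again beyond the limit. The estimate for compound 4 is 30000 nM, between 15000 nM and 100000 nM, and is expected to be reported as a limit rather than a number.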

Compound 4, half-maximal effective concentration: > 21500 nM
Compound 4 ended at the assay's limit; the forecaster's own chance of this, stated with the estimate: 85%; the middle value lies beyond the limit too.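

In this assay compound 4 gives > 21500 nM, a limit of the assay. With compound 3 also at a limit, no step can be read between compound 3 and compound 4, on this core or the other: the limit of > 21500 nM in this assay, at which 4 of the 4 values shown sit. The compounds shown leave open at what concentration, if any, each would reach its half-maximal effect in this assay, and whether methoxy and phenoxy differ there.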